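The source may report more compounds than this note shows. Statements on the series, on what has been measured and on what is new or still open speak of the compounds shown alone.

Compound 1 `CCN(CC)CCNC(=O)c1ccc(C(CC)(CC)c2ccc(OCS(=O)(=O)c3ccccc3)c(C)c2)n1CC` has the lowest number among three related compounds in a functional assay on MCF7 cells (Homo sapiens) for antiproliferative activity, read by MTT assay, with a stated time of 24 h (a lower number here means a stronger inhibitor, a higher number a weaker inhibitor), where compound 1 gives 4680 nM. Compound 2 `CCn1c(C(=O)N[C@H](C(=O)O)C(C)C)ccc1C(CC)(CC)c1ccc(OCS(=O)(=O)c2ccccc2)c(C)c1`, with 1-carboxy-2-methylpropyl in place of 2-(diethylamino)ethyl on the amide-type nitrogen, gives 24500 nM. That is a 5.2-fold higher number from compound 1 to compound 2 (0.72 log units; beyond the scatter). Compound 3 `CCn1c(C(=O)NCCC(=O)O)ccc1C(CC)(CC)c1ccc(OCS(=O)(=O)c2ccccc2)c(C)c1` reaches only a limit of the assay, > 50000 nM. Measured against that limit, the change is an at least 10-fold higher number from compound 1 to compound 3 (1.02 log units; beyond the scatter).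

Compound 4 `CCN(CC)CCNC(=O)c1ccc(C(CC)(CC)c2ccc(OCS(C)(=O)=O)c(C)c2)n1CC` keeps the 2-(diethylamino)ethyl group of compound 1 and instead has methyl in place of phenyl on a sulfonyl sulfur. For the measured compounds named here, none of the measured steps touches that sulfur, since all of them change the group on the amide-type nitrogen. They therefore bear on this change only indirectly, by showing how far the number in this assay has moved within this small set, from a 5.2-fold higher number from compound 1 to compound 2 (0.72 log units; beyond the scatter) to an at least 10-fold higher number from compound 1 to compound 3 (1.02 log units; beyond the scatter). Going by the values given here, with no direct precedent, only a modest move towards a higher number is expected. The expected step is a 2.1-fold higher number from compound 1 to compound 4 (0.33 log units; beyond the scatter). Compound 4 is estimated at 10000 nM, with an expected range from 3000 nM to 35000 nM.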

Compound 4, half-maximal inhibitory concentration: 14700 nM
Compound 4: middle estimate off by 1.5-fold (0.17 log units), on the low side, within the range that was stated.
By their numbers in this assay, from the lowest: compound 1; then compounds 4 and 2 (each within the scatter of the next). At a limit, above all of these: compound 3.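

Replacing phenyl with methyl on the sulfonyl sulfur, with the 2-(diethylamino)ethyl group held fixed, raises the number in this assay (a 3.1-fold higher number from compound 1 to compound 4 (0.50 log units; beyond the scatter)), a change beyond the scatter. For the compounds shown here, this shows that the number responds to the group on this sulfur as well as to the group on the amide-type nitrogen, the only place changed among the earlier compounds, and that here phenyl gives the lower number of the two. No measurement shown gives a property of either group that could account for this step, so it stands as an observation on this single pair.

The compounds shown leave open how the number would respond to groups on the sulfonyl sulfur other than phenyl and methyl, such as ethyl, benzyl or a chlorophenyl, and so whether the aromatic ring itself matters or any larger carbon group would serve as well. They also leave open whether the same change from phenyl to methyl gives a similar step when the amide-type nitrogen carries a carboxylic acid chain instead of the diethylamino chain.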